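Amide acyl group variation at the low end of the series

This account rests on a few compounds, and the source may have more. Where it says the series, first, only, none or still open, it means among the compounds named here.

Compound 1 `CCC(=O)NCCC(=O)c1cc(OC)ccc1N` is the smaller of the two measured amides. In an assay for inhibition of Nitric oxide synthase, inducible (Homo sapiens), read by scintillation counting, with a stated time of 30 min, tested at 1 mM (a higher number here means more inhibition at the concentration tested (going by the name of the read-out), a lower number less inhibition), compound 1 gives 0.24%, the lowest of the two numbers seen, with compound 2 `CCCCC(=O)NCCC(=O)c1cc(OC)ccc1N` the nearest neighbour. In this assay compound 2 gives 14.1%. Within the data shown here, the one measured step, a number 13.9 percentage points higher from compound 1 to compound 2 (beyond the scatter), comes from ethyl in place of hydrogen on a saturated chain carbon, two bonds along the chain from a carbonyl carbon.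

Compound 3 `COc1ccc(N)c(C(=O)CCNC(=O)C2CCCCC2)c1` is not yet measured. It differs from compound 1 in one place: cyclohexyl in place of ethyl on a carbonyl carbon. Among the measured compounds shown here, the change is again an enlargement of the carbon group on the amide carbonyl carbon, larger than the one separating compound 1 from compound 2, but a ring enters rather than a longer chain, so the measured step bears on it in direction more than in size. On that basis an upward move beyond the scatter is expected in this assay, of roughly the size seen with compound 2, with wide uncertainty since no ring-bearing amide has been measured. Compound 3 is therefore estimated at 15%, within 0% to 35%, an expected step of a number 14.8 percentage points higher from compound 1 to compound 3 (beyond the scatter).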

Compound 3, a percentage reported as inhibition, at one concentration (the size of the read-out at that concentration, not a potency): 9.24%
The estimate for compound 3 lay 5.8 percentage points above the measured number; the measured number falls inside the stated range.
By their numbers in this assay, from the lowest: compounds 1, 3 and 2 (each within the scatter of the next, the first and the last beyond it).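

In this assay a ring on the carbonyl carbon can now be set against open chains at the same place: cyclohexyl in place of ethyl gives a number 9 percentage points higher from compound 1 to compound 3 (within the scatter) and cyclohexyl in place of butyl gives a number 4.9 percentage points lower from compound 2 to compound 3 (within the scatter). Compound 3 therefore cannot be separated from either open-chain amide, even though those two lie apart beyond the scatter, so this result neither extends nor contradicts the rise seen on enlarging the chain. No accompanying data bear on the reason for this result.

Among these compounds, it remains open whether enlarging the group on the carbonyl carbon gives any gain clear of the scatter beyond the one step between the two open-chain amides, and a phenyl ring, a cyclopentyl ring or a longer chain such as hexyl at this place would test that. Also open, as far as these compounds go, is how far the numbers depend on the shared core, for instance on its amine or methoxy group, since all three compounds carry the same core and differ only on the carbonyl carbon.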